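This account rests on a few compounds, and the source may have more. Where it says the series, first, only, none or still open, it means among the compounds named here.

Of the compounds shown here, three have been measured in a functional assay for inhibition, with Homo sapiens as the target; a lower number here means a stronger inhibitor, a higher number a weaker inhibitor. Compound 3 `Cc1cccc(Nc2nccc(-c3cccs3)n2)c1` gives 300 nM. Compound 1 `Cc1cccc(Nc2nccc(-c3ccccn3)n2)c1` gives 700 nM. Compound 2 `c1csc(-c2ccnc(Nc3ccc(-n4ccnc4)cc3)n2)c1` gives 4300 nM, the highest of the three numbers.

Compounds 3 and 1 share a core and differ in one place: pyridin-2-yl in place of thiophen-2-yl on an aromatic carbon. That change made a measurable step, a 2.3-fold higher number from compound 3 to compound 1 (0.37 log units; beyond the scatter), so the pyridin-2-yl compound is the weaker inhibitor of the pair.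

Compound 4 `c1ccc(-c2ccnc(Nc3ccc(-n4ccnc4)cc3)n2)nc1` has not been measured in this assay. It differs from compound 2 in one place: pyridin-2-yl in place of thiophen-2-yl on an aromatic carbon. For the measured compounds named here, this is the same kind of change as the one from compound 3 to compound 1, though not the same change, since the two place descriptions differ in their words: in one case the place is meta to a group of 8 heavy atoms, in the other meta to a large group. The difference between the core of compound 2 and the core of compound 3 is not broken down here.

Compound 4 is expected to follow the earlier step, so a step of a 2.3-fold higher number from compound 2 to compound 4 (0.37 log units; beyond the scatter) is estimated, resting on the step of a 2.3-fold higher number from compound 3 to compound 1 (0.37 log units; beyond the scatter) and on the value of compound 2, 4300 nM. On that basis compound 4 is expected to give about 10000 nM in this assay, with a plausible range from 4000 nM to 25000 nM.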

Compound 4, half-maximal inhibitory concentration: 1400 nM
Beside the measured number, compound 4's estimate is 7.1-fold (0.85 log units) above it; measured number outside the range, below it.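

In this assay, putting pyridin-2-yl in place of thiophen-2-yl gives a 3.1-fold lower number from compound 2 to compound 4 (0.49 log units; beyond the scatter), so on this core the pyridin-2-yl compound is the stronger inhibitor of the pair, the reverse of the earlier result. The same change therefore moves the number in opposite directions on the two cores, and the gap between the two steps is larger than repeated measurements would be expected to produce: the same change on two cores in this assay, a 2.3-fold higher number (0.37 log units; beyond the scatter) from compound 3 to compound 1 and a 3.1-fold lower number (0.49 log units; beyond the scatter) from compound 2 to compound 4, 7.2-fold (0.86 log units) apart, beyond the scatter of two such steps This shows that, across these two pairs, neither the size nor the direction of the change carries over from one core to the other, so a step measured on one core is a poor guide to the other, but it does not show why the two cores differ, or which part of them is responsible, and two pairs cannot establish a rule for the wider series.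

The compounds shown leave open whether a third core, for instance one carrying an amine or a carboxylic acid, would follow the pair of compound 2 and compound 4 or the pair of compound 3 and compound 1. They also leave open how a plain phenyl or a furan-2-yl group would compare with thiophen-2-yl and pyridin-2-yl at this same place on each core.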